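Methylbenzyl analogues in the xanthine-type series: compound 4

The compounds below may be only part of what the source reports. "The series", "measured", "known", "first", "only" and "open" are said of these compounds alone.

Measured so far:
compound 1 `CCCn1c(=O)c2nc(-c3cnn(Cc4cccc(C)c4)c3)[nH]c2n(CCC)c1=O` gives 48 nM
compound 2 `CCCn1c(=O)c2nc(-c3cnn(Cc4c(F)cccc4F)c3)[nH]c2n(CCC)c1=O` gives "not determined" (no result reported)
compound 3 `CCn1c(=O)c2nc(-c3cnn(Cc4ccccc4)c3)[nH]c2n(CC)c1=O` gives 580 nM

In an assay on CHO cells for displacement of a labelled ligand from adenosine receptor A1 (Homo sapiens) (on this read-out higher numbers stand for weaker inhibition and lower numbers for stronger inhibition), compound 1 gives 48 nM and compound 3 gives 580 nM; these two differ in both the chains on the core and the substituent on the benzyl ring, so neither difference can be read on its own. Compound 2 `CCCn1c(=O)c2nc(-c3cnn(Cc4c(F)cccc4F)c3)[nH]c2n(CCC)c1=O` stands nowhere on these numbers: in this assay compound 2 gives "not determined" (no result reported), so the step to compound 4 starts from an empty point.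

Compound 4 `CCCn1c(=O)c2nc(-c3cnn(Cc4ccccc4C)c3)[nH]c2n(CCC)c1=O` differs from compound 2 by 2-methylphenyl in place of 2,6-difluorophenyl on a saturated chain carbon bound to an aromatic nitrogen. With no value for compound 2, neither the size nor the direction of this step in this assay can be anchored; no change beyond the scatter is assigned to it. Compound 4 shares its chains with compound 1 and carries a methylbenzyl group as compound 1 does, so compound 1 at 48 nM is the nearest measured point.

Compound 4 is expected to give about 80 nM in this assay, within a range of 20 nM to 400 nM.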

Compound 4, inhibition constant: 22 nM
Estimate against measurement, compound 4: 3.6-fold (0.56 log units) above, and the stated range covers the measured number.
By their numbers in this assay, from the lowest: compound 4; then compound 1; then compound 3.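

In this assay, 2-methylphenyl in place of 3-methylphenyl on a saturated chain carbon bound to an aromatic nitrogen gives a 2.2-fold lower number from compound 1 to compound 4 (0.34 log units; beyond the scatter). Among these compounds, this is the first comparison that differs in one place only: with the chains and the shared core unchanged, the location of the methyl group on the benzyl ring alone moves the number beyond the scatter. No measurement among these compounds bears on the reason for this step.

With no number for compound 2, the change from 2,6-difluorobenzyl to 2-methylbenzyl cannot be read, and compound 1 and compound 3 still differ in two places. From the compounds shown here alone, it remains open whether a methoxy group or a chlorine atom in place of the methyl group would keep the number of compound 4 near 22 nM.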